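Chloro in place of bromo: a one-atom swap

The compounds below may be only part of what the source reports. "The series", "measured", "known", "first", "only" and "open" are said of these compounds alone.

Of the compounds shown here, three built on the same core have been measured in a physicochemical assay for pharmacokinetics; a higher number here means that the compound lasts longer, a lower number that the compound disappears faster. Compound 1 `O=C(NCC1CCCCC1)N1C(=O)c2ccccc2S1(=O)=O` gives 0.963 h. Compound 2 `O=C(NCc1ccccc1Br)N1C(=O)c2ccccc2S1(=O)=O` gives 0.253 h, and compound 3 `O=C(NCc1cccc2ccccc12)N1C(=O)c2ccccc2S1(=O)=O` gives 0.395 h. Compound 2 thus shows the lowest of the three numbers; its value and that of compound 3 lie within the scatter of each other, whereas compound 1 stands clearly apart, the step of a 3.8-fold lower number from compound 1 to compound 2 (0.58 log units; beyond the scatter) being beyond the scatter.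

Compound 4 `O=C(NCc1ccccc1Cl)N1C(=O)c2ccccc2S1(=O)=O` is the next to be measured. Relative to compound 2 it carries chloro in place of bromo on an aromatic carbon. Among the compounds with values here, the single measured step, a 3.8-fold lower number from compound 1 to compound 2 (0.58 log units; beyond the scatter), sets a cyclohexyl against a 2-bromophenyl and so says nothing about exchanging one halogen for another; no measured pair differs only in bromo against chloro. With nothing pointing in either direction, the step expected in this assay is one within the scatter, namely a 1.2-fold higher number from compound 2 to compound 4 (0.07 log units; within the scatter). Compound 4 is therefore estimated at 0.3 h, with a range running from 0.15 h to 0.6 h.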

Compound 4, half-life: 0.42 h
Compound 4: middle estimate off by 1.4-fold (0.15 log units), on the low side, and the stated range covers the measured number.
By their numbers in this assay, from the lowest: compounds 2, 3 and 4 (each within the scatter of the next); then compound 1.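

In this assay, within the data shown here, this is the first exchange of one halogen for another on an aromatic carbon ortho to a large group, and it gives a 1.7-fold higher number from compound 2 to compound 4 (0.22 log units; within the scatter), so at this position bromo and chloro cannot be told apart. The earlier step changed the whole cyclohexyl group and could not show this. The new comparison with cyclohexyl gives a 2.3-fold lower number from compound 1 to compound 4 (0.36 log units; beyond the scatter), which shows that the separation from compound 1 seen with 2-bromophenyl also holds with 2-chlorophenyl, and no measurement at hand accounts for either step.

From the compounds shown here alone, with only two halogens at this position, it remains open whether a different kind of group on the same carbon, such as methoxy, a nitrile, an amine or a carboxylic acid, would take the half-life beyond the scatter, or whether a plain phenyl with hydrogen there would read like the halogen compounds. Going by these compounds, it is also open whether chloro on another carbon of the ring would behave as it does here, and whether a halogen on the cyclohexyl group would change the number at all.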